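Swapping a Benzyl Arm for a Benzoyl Arm

The source may hold more compounds than are shown below. What is called first, only, known or untested is meant among the compounds shown, and "the series" means these compounds.

Of the compounds shown here, three have been tested so far in a functional assay on HepG2 cells (Homo sapiens) for cytotoxicity, read by MTT assay, with a stated time of 72 h; a higher number here means a weaker inhibitor, a lower number a stronger inhibitor. Compound 1 `N#Cc1ccc(CN2CCC(NC(=O)COc3ccc4c(=O)cc(-c5ccccc5)oc4c3)CC2)cc1` gives 9300 nM, the higher of the two numbers measured. Compound 2 `COc1ccc(CN2CCC(NC(=O)C(C)(C)Oc3ccc(-c4cc(=O)c5ccccc5o4)cc3)CC2)cc1` gives 2800 nM in this assay, a gap beyond the usual scatter. Compound 3 `N#Cc1ccc(CN2CCC(NC(=O)COc3ccc4c(=O)c(-c5ccccc5)coc4c3)CC2)cc1` gives > 20000 nM, which is a limit of this assay and not a number, as the limit of > 20000 nM in this assay, at which 1 of the 3 values shown sits, records. Compound 4 `O=C(COc1ccc2c(=O)cc(-c3ccccc3)oc2c1)NC1CCN(C(=O)c2ccccc2)CC1` is compound 1 with a single change: benzoyl in place of 4-cyanobenzyl on an amine nitrogen in a ring. Within the data shown here, no measured pair differs in just this way, so the size of the step is open; the change is expected to move the number only modestly, if at all beyond the scatter. The estimate for compound 4 in this assay is 12000 nM, between 4000 nM and 30000 nM, meaning an expected step of a 1.3-fold higher number from compound 1 to compound 4 (0.11 log units; within the scatter).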

Compound 4, half-maximal inhibitory concentration: > 20000 nM
Compound 4: only a limit was reported; the forecaster's own chance of this, stated with the estimate: 30%; middle value at least 1.6-fold (0.22 log units) away from the limit.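

Benzoyl in place of 4-cyanobenzyl on the amine nitrogen in the ring gives an at least 2.1-fold higher number from compound 1 to compound 4 (0.33 log units; beyond the scatter) in this assay, the first single-place step in this set, so the group at this position can change the result. Compound 4 gives a limit and not a number, so the step has a floor but no measured size: the limit of > 20000 nM in this assay, at which 2 of the 4 values shown sit.

Still open, as far as these compounds go, is whether the carbonyl that enters or the nitrile that leaves accounts for the step. A plain benzyl or a 4-cyanobenzoyl group on this nitrogen would separate the two.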